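Adding methoxy to the phenyl ring of compound 2

The source may report more compounds than this note shows. Statements on the series, on what has been measured and on what is new or still open speak of the compounds shown alone.

Measured in a functional assay on HCT-116 cells (Homo sapiens) for antiproliferative activity, read by MTT assay, with a stated time of 72 h; on this read-out higher numbers stand for weaker inhibition and lower numbers for stronger inhibition:
- compound 1 (`C=CC(=O)Nc1nc(-c2ccccc2OC)cs1`) gives > 30000 nM (a limit)
- compound 2 (`C=CC(=O)N(Cc1cc(C)no1)c1nc(-c2ccccc2)cs1`) gives > 30000 nM (a limit)

Compound 2 stands at > 30000 nM, which is a limit of the assay and not a number. For the measured compounds named here, neither measured compound gives more than this: the series so far shows (the limit of > 30000 nM in this assay, at which 2 of the 2 values shown sit). Compound 3 (`C=CC(=O)N(Cc1cc(C)no1)c1nc(-c2ccccc2OC)cs1`) carries one change from compound 2 (methoxy in place of hydrogen on an aromatic carbon), methoxy in place of hydrogen on an aromatic carbon, which turns phenyl into 2-methoxyphenyl.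

No measured step sizes this change. A modest move towards stronger inhibition in this assay is expected, though a result at the same limit remains quite possible. For compound 3 the expected value is 10000 nM, with an estimated range from 2000 nM to 30000 nM. This estimate means an expected step of an at least 3.0-fold lower number from compound 2 to compound 3 (0.47 log units; beyond the scatter).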

Compound 3, half-maximal inhibitory concentration: > 30000 nM
Compound 3 gave a limit, no number; the forecaster's own chance of this, stated with the estimate: 50%; middle value at least 3.0-fold (0.47 log units) away from the limit.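

In this assay compound 3 gives > 30000 nM, which is a limit and not a number. No step from compound 1 or compound 2 to compound 3 can be read: the limit of > 30000 nM in this assay, at which 3 of the 3 values shown sit.

The compounds shown leave open whether methoxy or (3-methyl-1,2-oxazol-5-yl)methyl changes inhibition at all.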